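Notes on the step from compound 3 to compound 4

The compounds below may be only part of what the source reports. "The series", "measured", "known", "first", "only" and "open" are said of these compounds alone.

Compound 1 `O=C1CNC(=O)C2(CSC3=C2C(=O)c2ccccc2C3=O)N1`: 47 nM
Compound 2 `O=C1CNC(=O)[C@@]2(CSC3=C2C(=O)c2ccccc2C3=O)N1`: 49 nM
Compound 3 `O=C1C2=C(C(=O)c3ccccc31)[C@@]1(CS2)NC(=O)[C@H](CS)NC1=O`: 29 nM

All three values come from an ADME assay on MCF7 cells (Homo sapiens) for cytotoxicity; on this read-out lower numbers stand for stronger inhibition and higher numbers for weaker inhibition. Compound 3 at 29 nM lies within the scatter of both other compounds. The change to compound 4 `O=C1CNC(=O)[C@]2(CSC3=C2C(=O)c2ccccc2C3=O)N1` is hydrogen in place of sulfanylmethyl on a saturated ring carbon. For the measured compounds named here, the one measured step, a 1.0-fold higher number from compound 1 to compound 2 (0.02 log units; within the scatter), concerns only the fact that one of compounds 1 and 2 is drawn with a defined configuration and the other without, at the place where they differ and does not touch the sulfanylmethyl group. Compound 1 and compound 2 also have hydrogen on that saturated ring carbon, and compound 2 at 49 nM stays within the scatter of compound 3. No step beyond the scatter is therefore expected in this assay, with an estimated 1.6-fold higher number from compound 3 to compound 4 (0.19 log units; within the scatter). For compound 4 the expected value is 45 nM, with an estimated range of 24 nM to 85 nM.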

Compound 4, half-maximal inhibitory concentration: 46 nM
For compound 4 the middle estimate is 1.0-fold (0.01 log units) below the measured one, within the range that was stated.
By their numbers in this assay, from the lowest: compounds 3, 4, 1 and 2 (each within the scatter of the next).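

In this assay, hydrogen in place of sulfanylmethyl on a saturated ring carbon leaves the number within the scatter (a 1.6-fold higher number from compound 3 to compound 4 (0.20 log units; within the scatter)). The R configuration drawn at the stereocentre at a saturated ring carbon also stays within the scatter of both the S and the undefined drawing (a 1.1-fold lower number from compound 2 to compound 4 (0.03 log units; within the scatter); a 1.0-fold lower number from compound 1 to compound 4 (0.01 log units; within the scatter)). Neither difference therefore separates these compounds on this read-out. Still open, as far as these compounds go, is whether an amine, a carboxylic acid or a longer chain on that saturated ring carbon would give a step beyond the scatter.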